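Swapping the anilino aryl group on a shared urea core

The source may report more compounds than this note shows. Statements on the series, on what has been measured and on what is new or still open speak of the compounds shown alone.

Measured compounds:
compound 1 `COc1cc(NC(=O)Nc2cc(Nc3ccc(C)c(F)c3)ncn2)cc(OC)c1`, 39.7%
compound 2 `Cc1ccc(Nc2cc(NC(=O)Nc3c(Cl)cccc3Cl)ncn2)cc1C`, 41.3%
compound 3 `CC(C)(C)c1ccc(Nc2cc(NC(=O)Nc3c(Cl)cccc3Cl)ncn2)cc1`, 40%

In a functional assay on NCI-H226 cells (Homo sapiens) for inhibition, read by MTT assay, with a stated time of 48 h, tested at 10 uM (a lower number here means less inhibition, a higher number more inhibition at the concentration tested (going by the name of the read-out)), compound 1 gives 39.7%. Compound 2 gives 41.3% and compound 3 gives 40% in this assay, and the gaps between compound 1 and each of them lie within the usual scatter, so the three numbers cannot be told apart. Compound 4 `CCc1ccc(Nc2cc(NC(=O)Nc3cc(OC)cc(OC)c3)ncn2)cc1` has not yet been tested in this assay. It differs from compound 1 in one place: 4-ethylphenyl in place of 3-fluoro-4-methylphenyl on a nitrogen on an aromatic ring. With all three measured values so close together, no change beyond the scatter is expected; the step from compound 1 to compound 4 in this assay is estimated at a number 0.3 percentage points higher from compound 1 to compound 4 (within the scatter). Compound 4 is accordingly expected to give 40% in this assay, within a range of 28% to 52%.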

Compound 4, a percentage reported as inhibition, at one concentration (the size of the read-out at that concentration, not a potency): 50.1%
For compound 4 the middle estimate is 10.1 percentage points below the measured one, within the range that was stated.
By their numbers in this assay, from the lowest: compounds 1, 3, 2 and 4 (each within the scatter of the next, the first and the last beyond it).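

The aryl group on this nitrogen is not indifferent: in this assay, 4-ethylphenyl in place of 3-fluoro-4-methylphenyl gives a number 10.4 percentage points higher from compound 1 to compound 4 (beyond the scatter) and so moves the read-out beyond the scatter. The earlier compounds shown here, with no pair differing in one place, could show nothing about this position. Nothing at hand accounts for the rise. The swap removes the fluorine and alters the alkyl group together, and the compounds shown do not separate the two. From the compounds shown here alone, how a propyl chain or an amine on this phenyl ring would fare also stays open.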